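The source may report more compounds than this note shows. Statements on the series, on what has been measured and on what is new or still open speak of the compounds shown alone.

In an ADME assay on BJ cells (Homo sapiens) for cytotoxicity, read by CellTiter-Glo and resazurin assay, with a stated time of 72 h (a higher number here means that more compound is needed for the effect, a lower number that less compound is needed), compound 1 `CC(C)N(Cc1cccc(OCCCCCC(=O)O)c1)C(=O)c1ccc(-c2cccc3ccccc23)cc1` gives < 1.3 nM, which is a limit of the assay rather than a number. Compound 2 `CC(C)N(Cc1cccc(OCCCCCC(=O)O)c1)C(=O)c1ccc(-c2ccc(Cl)c(Cl)c2)cc1` gives > 26000 nM in this assay, again a limit. Compound 3 `CCOC(=O)CCCCCOc1cccc(CN(C(=O)c2ccc(-c3cccc4ccccc34)cc2)C(C)C)c1` also sits at a limit in this assay, giving > 26000 nM. For the measured compounds named here, of the three values known so far, compound 3 thus stands at the upper edge together with compound 2, while compound 1 stands at the lower edge; the gap between them appears as an at least 20000-fold higher number from compound 1 to compound 2 (4.30 log units; beyond the scatter) and as an at least 20000-fold higher number from compound 1 to compound 3 (4.30 log units; beyond the scatter), both reaching the edge described by the limit of > 26000 nM in this assay, at which 2 of the 3 values shown sit, with compound 1 at the limit of < 1.3 nM in this assay, at which 1 of the 3 values shown sits.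

Compound 4 `CCOC(=O)CCCCCOc1cccc(CN(C(=O)c2ccc(-c3cccc(OC(C)C)c3)cc2)C(C)C)c1` is the next compound, and it differs from compound 3 in one place: 3-isopropoxyphenyl in place of naphthalen-1-yl on an aromatic carbon. The step from compound 1 to compound 2, in which the naphthalen-1-yl group was exchanged for another aryl group, was large and went toward the upper limit, and compound 3 already sits at that limit with its ethyl ester kept. Both measured steps therefore point to a number for compound 4 that stays at the upper edge of this assay rather than returning toward compound 1, and the step is expected to be a step that the limit leaves unreadable from compound 3 to compound 4, which is to say no movement beyond the scatter from where compound 3 already stands. Compound 4 is accordingly expected to give about 30000 nM, within a range of 10000 nM to 100000 nM, most likely reported only as a limit, which becomes clear once compound 4 is measured.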

Compound 4, half-maximal effective concentration: > 26000 nM
Compound 4 was reported as a limit (the forecaster's own chance of this, stated with the estimate: 85%); the middle value lies beyond the limit too.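

In this assay compound 3 and compound 4 are both reported only as a limit, the same upper one, so no new step can be read between them. The compounds shown leave open how far past that limit each of the two lies, and whether 3-isopropoxyphenyl and naphthalen-1-yl differ at all on these ethyl esters in this assay.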